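A few compounds are considered here, and "the series" means these few. Any claim that something is new, unique, unknown or untested is made for them only; others in the source may bear on it.

Measured compounds:
compound 1, `CC(C)C[C@H](N)c1cc(C(F)(F)F)ccc1N1CCN(C(=O)COc2ccc3ccccc3c2)CC1`, 2000 nM
compound 2, `CC(C)C[C@H](N)c1cc(C(F)(F)F)ccc1N1CCN(C(=O)CCC(=O)N(C)C)CC1`, > 10000 nM

Within the data shown here, in an assay on HEK293 cells for displacement of a labelled ligand from Melanocortin receptor 4 (Homo sapiens) (on this read-out higher numbers stand for weaker inhibition and lower numbers for stronger inhibition), compound 1 gives 2000 nM, the only full number among the two values shown. Compound 2 gives > 10000 nM, which is a limit of the assay rather than a number. Among the measured compounds shown here, the one measured step is an at least 5.0-fold higher number from compound 1 to compound 2 (0.69 log units; beyond the scatter), ending at the limit of > 10000 nM in this assay, at which 1 of the 2 values shown sits. That step replaced the (naphthalen-2-yl)oxy group with (dimethylcarbamoyl)methyl, so the aromatic ring system on the oxygen was lost altogether.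

Compound 3, `CC(C)C[C@H](N)c1cc(C(F)(F)F)ccc1N1CCN(C(=O)COc2cccc(Cl)c2)CC1`, keeps the oxygen and carries the change (3-chlorophenyl in place of naphthalen-2-yl on an oxygen on a saturated carbon). For the measured compounds named here, the evidence bearing on this is indirect: the only measured step removed the aromatic group from that position and weakened binding at least modestly. Shrinking the group rather than removing it is expected to cost something, but probably less than the full removal did, so a modest weakening is expected a 2.0-fold higher number from compound 1 to compound 3 (0.30 log units; within the scatter). Compound 3 is therefore expected to give 4000 nM, within a range of 1500 nM to 12000 nM.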

Compound 3, inhibition constant: 2600 nM
Compound 3: the middle estimate sits 1.5-fold (0.19 log units) above what was measured; low and high end bracket the measured number.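

In this assay, placing 3-chlorophenyl, with one six-membered aromatic ring, where naphthalen-2-yl with its two had stood gives a 1.3-fold higher number from compound 1 to compound 3 (0.11 log units; within the scatter), so these two groups cannot be told apart on this read-out. Placing 3-chlorophenoxy where (dimethylcarbamoyl)methyl had stood gives an at least 3.8-fold lower number from compound 2 to compound 3 (0.58 log units; beyond the scatter), so compound 1 and compound 3, which both carry an aromatic ring on the oxygen, now each bind more strongly than compound 2, and the result no longer rests on the naphthalene-bearing compound 1 alone. The figure for compound 2 is a limit and not a number: the limit of > 10000 nM in this assay, at which 1 of the 3 values shown sits.

The compounds shown leave open whether the chlorine plays any part, a question that a plain phenoxy group at this position would address, and whether the oxygen matters, which a benzyl group in place of the 3-chlorophenoxy group would test. They also leave open whether a ring is needed at all, or whether a longer carbon chain ending in an amine could serve at this position as well.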